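This account rests on a few compounds, and the source may have more. Where it says the series, first, only, none or still open, it means among the compounds named here.

Compound 2 `Cc1cc(-c2c(C)nn(C)c2C)cnc1-c1nnc(N(C)Cc2ccc3ncc(-c4cnn(CCN(C)C)c4)n3c2)o1` arises from compound 1 `Cc1cc(-c2c(C)nn(C)c2C)cnc1-c1nnc(N(C)Cc2ccc3nccn3c2)o1` through a step that the two limits leave unreadable from compound 1 to compound 2. In an assay on COS-7 cells for inhibition of tyrosine-protein kinase receptor TYRO3 (Homo sapiens), read by ELISA, with a stated time of 1 h (on this read-out higher numbers stand for weaker inhibition and lower numbers for stronger inhibition), compound 1 gives > 31600 nM, which is a limit of the assay rather than a number. In this assay compound 2 likewise gives > 31600 nM, again a limit. Both sit at the limit of > 31600 nM in this assay, at which 2 of the 2 values shown sit, so the size of that step cannot be read. Compound 3 `Cc1cc(-c2c(C)nn(C)c2C)cnc1-c1nnc(N(C)Cc2ccc3ncc(-c4cccc(CN(C)C)c4)n3c2)o1` differs from compound 2 by 3-((dimethylamino)methyl)phenyl in place of 1-(2-(dimethylamino)ethyl)-1H-pyrazol-4-yl on an aromatic carbon. With both known values only limits, compound 3 is expected to stay weak, at an estimated 40000 nM with a range from 8000 nM to 200000 nM. The step expected is a step that the limit leaves unreadable from compound 2 to compound 3.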

Compound 3, half-maximal inhibitory concentration: > 31600 nM
Compound 3: no number, only a limit (the forecaster's own chance of this, stated with the estimate: 85%); the middle value lies beyond the limit too.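

In this assay, for the compounds shown here, compound 1, compound 2 and compound 3 all give only limits of the assay, so no step among them can be read. The compounds shown leave open how weak each one really is and whether any group at this place would give a readable value.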